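Ethoxy to Methyl: One Small Change, One Open Question

The compounds below may be only part of what the source reports. "The series", "measured", "known", "first", "only" and "open" are said of these compounds alone.

Of the compounds shown here, two have so far been tested in a functional assay on A549 cells (Homo sapiens) for cytotoxicity; a higher number here means a weaker inhibitor, a lower number a stronger inhibitor. Compound 1 `Cc1ccc(NC2=C(Cl)C(=O)c3ncncc3C2=O)cc1C` gives 4490 nM. Compound 2 `CCOc1ccccc1/N=C1/C(=O)c2cncnc2C(O)=C1Cl` gives 3280 nM in this assay. Going by the values given here, these two readings lie within the usual scatter of each other, so the data do not separate them: compound 2 is the one with the smallest number on the sheet, but that gap is the kind seen between repeat measurements of the same compound and carries no meaning on its own.

Compound 3 `Cc1ccccc1/N=C1/C(=O)c2cncnc2C(O)=C1Cl` has not yet been measured. It differs from compound 2 in a single place: methyl in place of ethoxy on an aromatic carbon. Among the compounds with values here, no pair of measured compounds shows this exact change, so there is no direct precedent for how large its effect might be. With only two measured points, and those two within scatter of one another, the reasonable expectation is a small step in either direction, most likely one that does not rise above the scatter. Compound 3 is therefore estimated at 3500 nM, with a range from 1500 nM to 8500 nM. The step this estimate implies, a 1.1-fold higher number from compound 2 to compound 3 (0.03 log units; within the scatter), is expected to be modest.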

Compound 3, half-maximal inhibitory concentration: 3600 nM
Compound 3: the middle estimate sits 1.0-fold (0.01 log units) below what was measured; low and high end bracket the measured number.
By their numbers in this assay, from the lowest: compounds 2, 3 and 1 (each within the scatter of the next).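

Methyl in place of ethoxy on an aromatic carbon, ortho to a large group, gives a 1.1-fold higher number from compound 2 to compound 3 (0.04 log units; within the scatter) in this assay and this is the first direct reading of that change. Ethoxy brings 3 heavy atoms and 1 hydrogen-bond acceptor while methyl brings 1 heavy atom and no acceptor, yet in this one pair that difference in counts produces no step that can be told apart from repeat measurement. No separate measurement on these compounds speaks to the reason for this result.

Going by these compounds alone, only this single swap at this single position has been read, so it remains open whether a fluorine atom, an amine, a carboxylic acid or a longer chain such as butoxy in the same place would also stay within the scatter or would move the number beyond it. As far as these compounds go, it is also open whether methyl and ethoxy would read alike on a different core, and no group at this position has yet given a step large enough to show that the position matters in this test.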